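The compounds below may be only part of what the source reports. "The series", "measured", "known", "first", "only" and "open" are said of these compounds alone.

In a functional assay on HT-29 cells (Homo sapiens) for cytotoxicity, read by MTT assay (on this read-out higher numbers stand for weaker inhibition and lower numbers for stronger inhibition), compound 1 `CC(=O)O[C@@H]1OC(=O)[C@@](Cc2ccccc2)(C(C)=O)[C@@H]1C` gives 39000 nM. Compound 2 `CC(=O)O[C@@H]1OC(=O)[C@@](O)(C(C)=O)[C@@H]1C` carries a hydroxy group in place of the benzyl group on a saturated ring carbon. In this assay compound 2 gives > 50000 nM, and this is a limit of the assay rather than a measured number. Compound 2 thus stands at the top end of what this assay reports, which is the limit of > 50000 nM in this assay, at which 1 of the 2 values shown sits, and only a range is known for it. The step of an at least 1.2-fold higher number from compound 1 to compound 2 (0.10 log units; that floor lies within the scatter) is a floor, and that floor lies within the usual scatter.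

Compound 3 `CC(=O)O[C@@H]1OC(=O)[C@@](OC(C)=O)(C(C)=O)[C@@H]1C` has not yet been measured. It differs from compound 2 by acetyl in place of hydrogen on an oxygen on a saturated carbon; read one bond further out, the change is hydroxy to acetoxy. Among the compounds with values here, the single measured step concerns a different exchange, benzyl to hydroxy, and gives no direct guide to an acetyl placed on the oxygen. Within the data shown here, with compound 2 at the limit and no measured step covering this change, compound 3 is expected to give 60000 nM in this assay, within a range from 20000 nM to 200000 nM. The expected step that the limit leaves unreadable from compound 2 to compound 3 amounts to none beyond the scatter, and a limit is again the likely outcome.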

Compound 3, half-maximal inhibitory concentration: > 50000 nM
Compound 3 was reported as a limit (the forecaster's own chance of this, stated with the estimate: 70%); the middle value does not contradict the limit.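

In this assay compound 3 gives > 50000 nM, which is a limit of the assay and not a number, so this position has now carried both hydroxy and acetoxy without a measured number from either: the limit of > 50000 nM in this assay, at which 2 of the 3 values shown sit.

The step between the two limits cannot be read, so the data do not tell whether placing acetyl on the oxygen changes the result at all. The comparison with the benzyl group gives an at least 1.2-fold higher number from compound 1 to compound 3 (0.10 log units; that floor lies within the scatter), so acetoxy, like hydroxy before it, cannot be separated from benzyl beyond the usual scatter.

The compounds shown leave open whether another group at this position, such as an amine, a methoxy group or a longer phenylpropyl chain, would give a measured number in this assay, and how that number would compare with compound 1 at 39000 nM. They also leave open what exchanges elsewhere on the shared core would do, for example replacing the acetoxy group on the other side of the core with an amine.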